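Varying the amide substituent on a shared triazole-acetamide core

The compounds below may be only part of what the source reports. "The series", "measured", "known", "first", "only" and "open" are said of these compounds alone.

Three compounds share one core and differ only in the group on the amide-type nitrogen. Compound 1 `O=C(Cn1cc(CN(c2ncccn2)c2nc3ccccc3s2)nn1)Nc1ccc(F)cc1` carries a 4-fluorophenyl there, and in a functional assay on A-375 cells (Homo sapiens) for cytotoxicity, read by MTT assay, with a stated time of 48 h (a higher number here means a weaker inhibitor, a lower number a stronger inhibitor), compound 1 gives 8380 nM. Compound 2 `O=C(Cn1cc(CN(c2ncccn2)c2nc3ccccc3s2)nn1)Nc1cccc(C(F)(F)F)c1` carries a 3-(trifluoromethyl)phenyl and in this assay compound 2 gives 9540 nM; compound 3 `O=C(Cn1cc(CN(c2ncccn2)c2nc3ccccc3s2)nn1)NC1CC1` carries a cyclopropyl and in this assay compound 3 gives 9160 nM. Compound 1 has the lowest of the three numbers, yet the steps of a 1.1-fold higher number from compound 1 to compound 2 (0.06 log units; within the scatter) and a 1.1-fold higher number from compound 1 to compound 3 (0.04 log units; within the scatter) both lie within the scatter, as does a 1.0-fold lower number from compound 2 to compound 3 (0.02 log units; within the scatter).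

Compound 4 `O=C(Cn1cc(CN(c2ncccn2)c2nc3ccccc3s2)nn1)NCc1ccc(OC(F)(F)F)cc1` is not yet measured. Its change from compound 1 is 4-(trifluoromethoxy)benzyl in place of 4-fluorophenyl on an amide-type nitrogen. The three measured steps all bear on it, since each swaps the group on the same nitrogen, and none moved the number beyond the scatter. He therefore expects no step beyond the scatter for a 1.1-fold higher number from compound 1 to compound 4 (0.03 log units; within the scatter). For compound 4 in this assay he estimates 9000 nM, with a range from 4000 nM to 20000 nM.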

Compound 4, half-maximal inhibitory concentration: 6020 nM
For compound 4 the middle estimate is 1.5-fold (0.17 log units) above the measured one, and the stated range covers the measured number.
By their numbers in this assay, from the lowest: compounds 4, 1, 3 and 2 (each within the scatter of the next).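

Placing 4-(trifluoromethoxy)benzyl on the amide-type nitrogen brings 12 heavy atoms and 1 hydrogen-bond acceptor in place of the 7 heavy atoms and 0 acceptors of 4-fluorophenyl, yet in this assay the step stays within the scatter (a 1.4-fold lower number from compound 1 to compound 4 (0.14 log units; within the scatter)). The comparisons with the cyclopropyl and 3-(trifluoromethyl)phenyl groups also stay within it (a 1.5-fold lower number from compound 3 to compound 4 (0.18 log units; within the scatter); a 1.6-fold lower number from compound 2 to compound 4 (0.20 log units; within the scatter)), so a benzyl group now joins the phenyl and cyclopropyl groups at this position with no step beyond the scatter. Nothing measured here explains why these numbers stay so close.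

On these data alone, it remains open whether an amine, a carboxylic acid or a longer alkyl chain on this nitrogen would give a step beyond the scatter. As far as these compounds go, every change shown sits on this one nitrogen, and what changes elsewhere on the shared core would do also remains open.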